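Swapping a chloropyrazine for a dichloropyrimidine amide

A few compounds are considered here, and "the series" means these few. Any claim that something is new, unique, unknown or untested is made for them only; others in the source may bear on it.

Measured so far:
compound 1 `N#Cc1ncc(C(=O)Nc2cc(C(F)(F)F)cc(C(F)(F)F)c2)c(C(F)(F)F)n1`: > 10000 nM
compound 2 `O=C(Nc1cc(C(F)(F)F)cc(C(F)(F)F)c1)c1cnc(Cl)cn1`: 4000 nM

Among the measured compounds shown here, in an assay on Jurkat cells for activation of nuclear factor NF-kappa-B complex (Homo sapiens) (a lower number here means a stronger inhibitor, a higher number a weaker inhibitor), compound 2 gives 4000 nM, the only plain number here. For compound 1 the value > 10000 nM is a limit of the assay, not a number. Compound 3 `O=C(Nc1cc(C(F)(F)F)cc(C(F)(F)F)c1)c1cc(Cl)nc(Cl)n1` keeps the amide and the bis(trifluoromethyl)phenyl part of compound 2 and changes the other ring: 2,6-dichloropyrimidin-4-yl in place of 5-chloropyrazin-2-yl on a carbonyl carbon. No measured step of this kind exists among these compounds, so the expected step from compound 2 to compound 3 is a 1.3-fold higher number from compound 2 to compound 3 (0.10 log units; within the scatter), within the usual scatter. Compound 3 is therefore estimated at 5000 nM, likely between 1500 nM and 20000 nM.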

Compound 3, half-maximal inhibitory concentration: > 10000 nM
Compound 3 ended at the assay's limit; the forecaster's own chance of this, stated with the estimate: 40%; middle value at least 2.0-fold (0.30 log units) away from the limit.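

The new compound shows that this ring, on a carbonyl carbon, cannot be swapped freely: in this assay, 2,6-dichloropyrimidin-4-yl in place of 5-chloropyrazin-2-yl gives an at least 2.5-fold higher number from compound 2 to compound 3 (0.39 log units; beyond the scatter). The value of compound 3 is a limit of the assay, not a number. The true size of the step therefore stays unknown because of this ceiling: the limit of > 10000 nM in this assay, at which 2 of the 3 values shown sit.

From the compounds shown here alone, the two rings differ both in their chlorine count and in ring type, so which difference matters remains open. Also open, going by these compounds, is whether a ring carrying an amine in place of chlorine would give a lower number than compound 2.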